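A trifluoromethyl step from a compound at the limit

A few compounds are considered here, and "the series" means these few. Any claim that something is new, unique, unknown or untested is made for them only; others in the source may bear on it.

In an ADME assay on MDBK cells (Bos taurus) for cytotoxicity, read by MTT assay, with a stated time of 96 h (a higher number here means that more compound is tolerated, a lower number that less compound is tolerated), compound 1 (`CC(=O)c1ccc2[nH]c(-c3ccccc3)nc2c1`) gives > 100000 nM, which is a limit of the assay and not a number. Compound 2 (`C/C(=N\O)c1ccc2[nH]c(-c3ccccc3)nc2c1`) gives > 100000 nM, again a limit and not a number. Compound 2 therefore has no exact value, and the picture so far is the limit of > 100000 nM in this assay, at which 2 of the 2 values shown sit.

Compound 3 (`C/C(=N\O)c1ccc2[nH]c(-c3ccc(C(F)(F)F)cc3)nc2c1`) differs from compound 2 by trifluoromethyl in place of hydrogen on an aromatic carbon. The new trifluoromethyl stands on an aromatic carbon of a six-membered aromatic ring of carbon only, para to a large group.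

Going by the values given here, only one measured step is available, a step that the two limits leave unreadable from compound 1 to compound 2. It concerns another part of the structure and gives no size to carry over, so the forecast in this assay is weakly grounded. A result at the same limit is quite possible, and any measurable number would have to lie on the less tolerated side. The expected change is therefore modest, and it is an at least 1.3-fold lower number from compound 2 to compound 3 (0.12 log units; that floor lies within the scatter). For compound 3 the estimated value is 75000 nM, with an expected range from 25000 nM to 100000 nM.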

Compound 3, half-maximal cytotoxic concentration: 55000 nM
The estimate for compound 3 lay 1.4-fold (0.13 log units) above the measured number, and the stated range covers the measured number.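

In this assay, trifluoromethyl in place of hydrogen on an aromatic carbon, para to a large group, gives an at least 1.8-fold lower number from compound 2 to compound 3 (0.25 log units; that floor lies within the scatter), and this is the only step shown that has a readable size. The step between the two earlier compounds cannot be read, and they offer no exact number to set beside that of compound 3: the limit of > 100000 nM in this assay, at which 2 of the 3 values shown sit. The new result therefore shows that a single change at this position can bring a value inside the measurable range of the assay, but the printed size is only a floor, so it does not fix how large the change really is.

On these data alone, whether this measurable value is particular to trifluoromethyl stays open, and a chlorine atom, a methoxy group or an amine on the same aromatic carbon would test that. As far as these compounds go, it is equally open whether the same trifluoromethyl change would give a measurable value on the core of compound 1, which carries a carbonyl where compound 2 carries its oxime.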